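The source may hold more compounds than are shown below. What is called first, only, known or untested is meant among the compounds shown, and "the series" means these compounds.

Measured so far:
compound 1, `COc1ccc(C(=O)/C(=C\c2ccc(O)c([N+](=O)[O-])c2)SCc2ccc(Br)cc2)cc1`, 10000 nM
compound 2, `O=C(/C(=C\c1ccc([N+](=O)[O-])c(O)c1)SCc1ccc(Br)cc1)c1ccc([N+](=O)[O-])c(Cl)c1`, 1000 nM
compound 3, `Cc1ccc(CS/C(=C/c2c[nH]c3ccc(Cl)cc23)C(=O)c2ccc(Cl)cc2)cc1`, 1000 nM

These three compounds were tested in a functional assay on DU-145 cells (Homo sapiens) for inhibition, read by trypan blue exclusion, with a stated time of 96 h; a higher number here means a weaker inhibitor of growth, a lower number a stronger inhibitor of growth. Compound 1 stands at the highest of the three numbers: its value, 10000 nM, lies beyond the scatter above both compound 2 and compound 3, each of which gives a lower number. Compound 2 and compound 3 sit at the same value, and nothing can be said of their order.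

The step under consideration leads from compound 1 to compound 4, `O=C(/C(=C\c1ccc(O)c([N+](=O)[O-])c1)SCc1ccc(Br)cc1)c1c(F)c(F)c(F)c(F)c1F`, which has not yet been measured in this assay. The change is 2,3,4,5,6-pentafluorophenyl in place of 4-methoxyphenyl on a carbonyl carbon. Among the measured compounds, the one that also carries a substituted aryl on its carbonyl carbon and shares the bromobenzyl thioether with compound 1 is compound 2, which gives 1000 nM, a lower number than compound 1. Among the measured compounds shown here, with only that comparison to lean on, a step downward of moderate size is expected, though with wide uncertainty, since no directly comparable pair has been measured.

Compound 4 is therefore estimated at 3000 nM, with a likely range from 800 nM to 10000 nM. The expected step is a 3.3-fold lower number from compound 1 to compound 4 (0.52 log units; beyond the scatter).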

Compound 4, concentration for 50% growth inhibition: 10000 nM
For compound 4 the middle estimate is 3.3-fold (0.52 log units) below the measured one; low and high end bracket the measured number.
By their numbers in this assay, from the lowest: compounds 2 and 3 (each within the scatter of the next); then compounds 1 and 4 (each within the scatter of the next).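

In this assay, among the compounds shown here, the exchange of 4-methoxyphenyl for 2,3,4,5,6-pentafluorophenyl on the carbonyl carbon shows no change at the digits printed from compound 1 to compound 4 (within the scatter) and so gives the first direct reading of a single change at this position. The entering group has more heavy atoms than the one it replaces and no hydrogen-bond acceptor where the leaving group has one, yet this pair shows no shift in growth inhibition. Within the core of compound 1, these two aryl groups therefore cannot be told apart at this position, though that rests on this one pair alone. No measured property is available to explain this result.

This single pair leaves open whether a different kind of group on the carbonyl carbon, such as a phenyl ring carrying an amine or a carboxylic acid, would move the number in either direction. It also leaves open whether the same exchange would read the same way on another core, such as that of compound 3.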